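Fluoro Added to a Cyanophenyl Amide: Cytotoxicity Outlook

The source may hold more compounds than are shown below. What is called first, only, known or untested is meant among the compounds shown, and "the series" means these compounds.

Compound 1 `Cc1cc(C#N)cc(C)c1Oc1ccnc(S(=O)(=O)CC(=O)Nc2ccccc2)n1`, compound 2 `Cc1cc(C#N)cc(C)c1Oc1ccnc(S(=O)(=O)CC(=O)Nc2cccc(F)c2)n1` and compound 3 `Cc1cc(C#N)cc(C)c1Oc1ccnc(S(=O)(=O)CC(=O)Nc2ccc(C#N)cc2)n1` share one core and differ only in the ring carried on the amide nitrogen. In an ADME assay on MT4 cells (Homo sapiens) for cytotoxicity, read by MTT assay, with a stated time of 4 days (a higher number here means that more compound is tolerated, a lower number that less compound is tolerated), compound 1 gives 29300 nM. Compound 2 gives 25900 nM in this assay. For compound 3 this assay reports only a limit, >= 6010 nM. The change from compound 1 to compound 2 is fluoro in place of hydrogen on an aromatic carbon, and it made a 1.1-fold lower number from compound 1 to compound 2 (0.05 log units; within the scatter). The steps a step that the limit leaves unreadable from compound 1 to compound 3 and a step that the limit leaves unreadable from compound 2 to compound 3 cannot be sized, as compound 3 sits at the limit of >= 6010 nM in this assay, at which 1 of the 3 values shown sits. Compound 4 `Cc1cc(C#N)cc(C)c1Oc1ccnc(S(=O)(=O)CC(=O)Nc2ccc(C#N)cc2F)n1` has not been measured. It differs from compound 3 by fluoro in place of hydrogen on an aromatic carbon, the same kind of change as from compound 1 to compound 2, though here the fluoro sits ortho to a large group and meta to a cyano group, whereas in compound 2 it sits meta to a large group. The cores of compound 1 and compound 3 differ by cyano in place of hydrogen on an aromatic carbon. The step that the limit leaves unreadable from compound 3 to compound 4 is expected to be small, resting on the earlier step of a 1.1-fold lower number from compound 1 to compound 2 (0.05 log units; within the scatter), which stayed within the scatter. Compound 4 is thus estimated at 20000 nM in this assay, between 7000 nM and 60000 nM, with a fair chance that only a limit is reported again.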

Compound 4, half-maximal cytotoxic concentration: > 268000 nM
Compound 4 ended at the assay's limit; the forecaster's own chance of this, stated with the estimate: 55%; middle value at least 13-fold (1.12 log units) away from the limit.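

In this assay, fluoro in place of hydrogen on an aromatic carbon gave a 1.1-fold lower number from compound 1 to compound 2 (0.05 log units; within the scatter), while changing the ring on the amide nitrogen gave an at least 10-fold higher number from compound 2 to compound 4 (1.01 log units; beyond the scatter) and an at least 9.1-fold higher number from compound 1 to compound 4 (0.96 log units; beyond the scatter), two steps that alter more than the fluoro alone. Compound 4 carries only a limit, > 268000 nM, and not a number. The step that would test the same fluoro change on the cyano-bearing core cannot be read, and neither can the other steps to compound 3, because compound 3 also carries only a limit: the limit of >= 6010 nM in this assay, at which 1 of the 4 values shown sits.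

The compounds shown leave open whether the fluoro change has any effect on the cyano-bearing core, or whether the high limit of compound 4 comes from the cyano group, the fluoro or the two together. They also leave open what an amine or a carboxylic acid in place of the cyano group would give in this assay.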